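Replacing (2-aminoethyl)amino with piperazin-1-yl on the shared core

This account rests on a few compounds, and the source may have more. Where it says the series, first, only, none or still open, it means among the compounds named here.

Compound 1 `CN(C)CCCNc1c(C(=O)NCc2ccc(F)cc2)nc(Br)c2cccnc12`: > 10000 nM (a limit)
Compound 2 `NCCNc1c(C(=O)NCc2ccc(F)cc2)nc(Br)c2cccnc12`: > 20000 nM (a limit)

In a functional assay on HCT-116 cells (Homo sapiens) for cytotoxicity, read by MTT assay, with a stated time of 72 h (a lower number here means a stronger inhibitor, a higher number a weaker inhibitor), compound 2 gives > 20000 nM, a limit and not a number. Compound 1 gives > 10000 nM, also a limit. Neither compound therefore has a measured potency to serve as a starting point.

Compound 3 `O=C(NCc1ccc(F)cc1)c1nc(Br)c2cccnc2c1N1CCNCC1` keeps the shared core but carries piperazin-1-yl in place of (2-aminoethyl)amino on an aromatic carbon.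

Within the data shown here, the only measured step, a step that the two limits leave unreadable from compound 1 to compound 2, also alters a side chain, but its size cannot be read. It offers no size to carry over to this change, so no step beyond the scatter is expected in this assay, and a further limit is the likeliest result.

The estimated value for compound 3 is 20000 nM, with an expected range of 6000 nM to 60000 nM. This estimate means an expected a number no higher from compound 2 to compound 3 (the limit leaves the size open).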

Compound 3, half-maximal inhibitory concentration: > 10000 nM
Compound 3: no number, only a limit; the forecaster's own chance of this, stated with the estimate: 65%; the middle value does not contradict the limit.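

Compound 1, compound 2 and compound 3 each give only a limit and not a number in this assay. The steps among them cannot be read. The compounds shown leave open whether any of these side chains on the shared core gives a measurable potency in this assay.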